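Methoxy to hydroxy on the dimethylaminophenyl pyrazole series

This account rests on a few compounds, and the source may have more. Where it says the series, first, only, none or still open, it means among the compounds named here.

Measured so far:
compound 1, `COc1cc(C)cc(-c2nn(CC#N)cc2-c2ccc(-c3cccc(C(C)=O)c3)nc2)c1`: 78%
compound 2, `Cc1cc(O)cc(-c2nn(CC#N)cc2-c2ccnc(-c3ccc(Oc4ccccc4)cc3)c2)c1`: 92%
compound 3, `COc1cc(C)cc(-c2nn(CC#N)cc2-c2ccnc(-c3ccc(N(C)C)cc3)c2)c1`: -31%

In a functional assay on SF-539 cells (Homo sapiens) for cytotoxicity, read by sulforhodamine B assay, with a stated time of 48 h, tested at 100 nM (on this read-out lower numbers stand for a stronger effect and higher numbers for a weaker effect at the one concentration tested), compound 3 gives -31%, the lowest of the three numbers and therefore the strongest effect seen here. Compound 1 gives 78% and compound 2 gives 92%, both far weaker than compound 3, each beyond the usual scatter. No two of these compounds differ in only one place, so no single step among them can be read off.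

Compound 4, `Cc1cc(O)cc(-c2nn(CC#N)cc2-c2ccnc(-c3ccc(N(C)C)cc3)c2)c1`, is not yet measured. It differs from compound 3 in one place:
hydrogen in place of methyl on an oxygen on an aromatic ring

Compound 2 also carries the hydroxy group, but it differs from compound 3 in a second place as well, so its weak number cannot be tied to the hydroxy alone. The step from compound 3 to compound 4 in this assay is expected to be upward and moderate, a number 36 percentage points higher from compound 3 to compound 4 (beyond the scatter), the effect weakening but compound 4 likely staying well below compound 1 and compound 2. Compound 4 is therefore expected to give 5%, within a range from -35% to 60%.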

Compound 4, a percentage reported as activity, at one concentration (the size of the read-out at that concentration, not a potency): 91%
The estimate for compound 4 lay 86 percentage points below the measured number; measured number outside the range, above it.
By their numbers in this assay, from the lowest: compound 3; then compound 1; then compounds 4 and 2 (each within the scatter of the next).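

In this assay, the methoxy of the 3-methoxy-5-methylphenyl group proves decisive: with the dimethylamino group held constant, hydroxy in its place gives a number 122 percentage points higher from compound 3 to compound 4 (beyond the scatter) and removes the strong effect seen with compound 3. Going by these compounds alone, with hydroxy in place, exchanging phenoxy for dimethylamino gives a number 1 percentage points lower from compound 2 to compound 4 (within the scatter), so this pair shows no difference from that exchange, a separation the earlier compounds could not make. Nothing available here explains the size of the methoxy to hydroxy step.

From the compounds shown here alone, it remains open whether the effect requires methoxy itself or would persist with an ethoxy or an amino group on that aromatic ring. Within the data shown here, it is also open whether dimethylamino contributes to the strong effect when methoxy is present, as no pair here tests that exchange in the methoxy setting.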